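The compounds below may be only part of what the source reports. "The series", "measured", "known", "first", "only" and "open" are said of these compounds alone.

In a functional assay on U-251 cells (Homo sapiens) for inhibition, read by sulforhodamine B assay, with a stated time of 48 h, tested at 10 uM (a higher number here means more inhibition at the concentration tested (going by the name of the read-out), a lower number less inhibition), compound 3 `c1cn2cc(-c3ccsc3)nc(-c3ccc4ncn(C5CCCCC5)c4c3)c2n1` gives 6.09%, the second highest of the three numbers, though its gap to compound 1 lies within the scatter. Compound 1 `Brc1cn2ccnc2c(-c2ccc3ncn(C4CCCCC4)c3c2)n1` gives 1.5%, and compound 2 `COc1ccc(-c2cn3ccnc3c(-c3ccc4ncn(C5CCCCC5)c4c3)n2)cc1` gives 80.9%. The steps that reach compound 3 are a number 4.6 percentage points higher from compound 1 to compound 3 (within the scatter) and a number 74.8 percentage points lower from compound 2 to compound 3 (beyond the scatter). Compound 4 `c1csc(-c2cn3ccnc3c(-c3ccc4ncn(C5CCCCC5)c4c3)n2)c1` differs from compound 3 by thiophen-2-yl in place of thiophen-3-yl on an aromatic carbon. Going by the values given here, no measured step exchanges one thiophenyl for the other; what is known is that bromo and thiophen-3-yl sit close together in this assay, while 4-methoxyphenyl stands far above both. The expected step is therefore a number 3.9 percentage points higher from compound 3 to compound 4 (within the scatter), within the scatter. Compound 4 is estimated to give 10%, in a range from 0% to 35%.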

Compound 4, a percentage reported as inhibition, at one concentration (the size of the read-out at that concentration, not a potency): 3.92%
Compound 4: middle estimate off by 6.1 percentage points, on the high side; measured number inside the range.
By their numbers in this assay, from the lowest: compounds 1, 4 and 3 (each within the scatter of the next); then compound 2.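

In this assay, swapping thiophen-3-yl for thiophen-2-yl leaves the reading essentially unchanged, with a number 2.2 percentage points lower from compound 3 to compound 4 (within the scatter) and with a number 2.4 percentage points higher from compound 1 to compound 4 (within the scatter). At this position, next to the ring nitrogen, the point of attachment of the thiophene therefore makes no visible difference, and both thiophenyl groups stay level with bromo, while the drop remains large, with a number 77 percentage points lower from compound 2 to compound 4 (beyond the scatter). No evidence is available to explain this gap. Going by these compounds, it remains open whether the high reading of compound 2 needs the methoxy group or only a phenyl ring, and how a phenyl ring carrying an amine or a carboxylic acid reads here.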